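The compounds below may be only part of what the source reports. "The series", "measured", "known", "first", "only" and "open" are said of these compounds alone.

Of the compounds shown here, three sharing one core have been measured so far in a functional assay on MIA PaCa-2 cells (Homo sapiens) for antiproliferative activity (on this read-out lower numbers stand for an effect already at smaller amounts and higher numbers for an effect only at larger amounts of compound), with these results: compound 1 (`C#CCNC(=O)c1cccc2c1cc(C)n2-c1nc2c(c(NCc3ccccc3)n1)CCCC2`) gives 470 nM and compound 2 (`CCCNC(=O)c1cccc2c1cc(C)n2-c1nc2c(c(NCc3ccccc3)n1)CCCC2`) gives 608 nM while compound 3 (`C#CC(=O)Nc1cccc2c1cc(C)n2-c1nc2c(c(NCc3ccccc3)n1)CCCC2`) gives 131 nM as the lowest number of the three. Compound 4 (`CCC#CC(=O)Nc1cccc2c1cc(C)n2-c1nc2c(c(NCc3ccccc3)n1)CCCC2`) differs from compound 3 in one place only: ethyl in place of hydrogen on a triple-bonded carbon (ethyl in place of hydrogen on a triple-bonded carbon, which turns ethynyl into but-1-yn-1-yl). Among the measured compounds shown here, no measured pair makes this exact change. The closest comparison is a 1.3-fold higher number from compound 1 to compound 2 (0.11 log units; within the scatter) for ethyl in place of ethynyl, but that swap is a different one on a different chain. For the measured compounds named here, the steps of a 3.6-fold lower number from compound 1 to compound 3 (0.55 log units; beyond the scatter) and a 4.6-fold lower number from compound 2 to compound 3 (0.67 log units; beyond the scatter) replace a whole group on an aromatic carbon, and they show only that changes in this part of the molecule can shift the number by a modest amount. With compound 3 at the low end of the series at 131 nM in this read-out, a modest move towards a higher number seems more likely than a further drop, though the data cannot settle this. The expected step in this assay is a 2.7-fold higher number from compound 3 to compound 4 (0.43 log units; beyond the scatter) as a rough estimate. For compound 4 the estimated value is 350 nM with an expected range from 100 nM to 1200 nM for now.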

Compound 4, half-maximal effective concentration: 463 nM
The estimate for compound 4 lay 1.3-fold (0.12 log units) below the measured number, and the stated range covers the measured number.
By their numbers in this assay, from the lowest: compound 3; then compounds 4, 1 and 2 (each within the scatter of the next).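

In this assay, among the compounds shown here, the far end of the triple bond proves sensitive to change: ethyl in place of hydrogen on this triple-bonded carbon gives a 3.5-fold higher number from compound 3 to compound 4 (0.55 log units; beyond the scatter), the first direct reading at this carbon. The low number of compound 3 therefore does not carry over to every alkyne on the same amide link, since the but-1-yn-1-yl group brings the molecule back level with the two carbamoyl compounds, with a 1.3-fold lower number from compound 2 to compound 4 (0.12 log units; within the scatter) and a 1.0-fold lower number from compound 1 to compound 4 (0.01 log units; within the scatter) both printed as within the scatter. No supporting measurement is available that could explain why the added ethyl has this effect.

A single substituent on this carbon cannot show whether the number climbs gradually with size or whether any addition at all is enough, so a methyl group or a longer chain such as butyl at the same place would be the informative comparison. On these data alone, it also remains open how a chain carrying an amine would behave there, and whether a saturated chain in place of the whole ethynyl group would keep or lose the low number of compound 3.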